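Phenyl to 4-acetylphenyl in the series

A few compounds are considered here, and "the series" means these few. Any claim that something is new, unique, unknown or untested is made for them only; others in the source may bear on it.

In a functional assay on HCT-116 cells (Homo sapiens) for inhibition, read by colorimetric assay, with a stated time of 3 days (a lower number here means a stronger inhibitor, a higher number a weaker inhibitor), compound 3 (`O=C(CCCCCCNC(=O)C(O)(O)C(F)(F)F)Nc1ccccc1`) gives 9140 nM and compound 1 (`O=C(CCCCCCNC(=O)C(O)(O)C(F)(F)F)Nc1ccncc1`) gives 6670 nM, so the two stand level: a 1.4-fold higher number from compound 1 to compound 3 (0.14 log units; within the scatter). Compound 2 (`O=C(CCCCCCNC(=O)c1cc(=O)c(O)co1)Nc1ccccc1`) reads > 100000 nM, which is a limit of the assay. The large at least 10-fold lower number from compound 2 to compound 3 (1.03 log units; beyond the scatter) concerns a group on a carbonyl carbon, not the aromatic ring.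

Compound 4 (`CC(=O)c1ccc(NC(=O)CCCCCCNC(=O)C(O)(O)C(F)(F)F)cc1`) carries acetyl in place of hydrogen on an aromatic carbon, which turns phenyl into 4-acetylphenyl. Only the change between compound 1 and compound 3 touches this aromatic group, and it stayed within the scatter. Going by the values given here, no measured step adds a group to this ring, so no change beyond the scatter is expected, in either direction. The expected step is a 1.1-fold lower number from compound 3 to compound 4 (0.06 log units; within the scatter). Compound 4 is estimated at 8000 nM, with an expected range of 3000 nM to 22000 nM.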

Compound 4, half-maximal inhibitory concentration: 12100 nM
Compound 4: the middle estimate sits 1.5-fold (0.18 log units) below what was measured; the range from low to high includes it.
By their numbers in this assay, from the lowest: compounds 1, 3 and 4 (each within the scatter of the next). At a limit, above all of these: compound 2.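

In this assay, acetyl is the first group shown on this phenyl ring, and at this place, para to a large group, it leaves the number level: a 1.3-fold higher number from compound 3 to compound 4 (0.12 log units; within the scatter). The 4-acetylphenyl and pyridin-4-yl ends also stand level: a 1.8-fold higher number from compound 1 to compound 4 (0.26 log units; within the scatter). No measurement at hand bears on a cause for these readings.

Open, on these data alone, is whether an amine or a carboxylic acid in place of acetyl would move the number beyond the scatter. As far as these compounds go, a longer chain in the shared core also remains open.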